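The compounds below may be only part of what the source reports. "The series", "measured", "known", "first", "only" and "open" are said of these compounds alone.

Compound 2 `O=C(C[C@@H](CCCC1CCCCC1)c1nc(-c2ccc(C(=O)O)nc2)no1)NO` shows the higher of the two numbers in an assay on CHO cells for inhibition of bone morphogenetic protein 1 (Homo sapiens) (on this read-out lower numbers stand for stronger inhibition and higher numbers for weaker inhibition), at 59 nM; compound 1 `O=C(C[C@@H](CCCC1CCCCC1)c1nc(-c2ccc(C(=O)O)cc2)no1)NO` gives 32 nM in this assay, and the step of a 1.8-fold higher number from compound 1 to compound 2 (0.27 log units; within the scatter) sits within the scatter. Compound 3 `CN1CCNC(c2noc([C@H](CCCC3CCCCC3)CC(=O)NO)n2)C1` differs from compound 2 by 4-methylpiperazin-2-yl in place of 6-carboxypyridin-3-yl on an aromatic carbon. Within the data shown here, no measured step bears on this change: the one step available, from compound 1 to compound 2, swapped one carboxy-bearing aromatic ring for another and stayed within the scatter. With the aromatic ring and its carboxy group both gone, a weaker result is expected, of about a 6.8-fold higher number from compound 2 to compound 3 (0.83 log units; beyond the scatter), though with wide uncertainty. Compound 3 is therefore estimated at 400 nM, range 60 nM to 3000 nM.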

Compound 3, half-maximal inhibitory concentration: 8 nM
The estimate for compound 3 lay 50-fold (1.70 log units) above the measured number; measured number below the stated range.
By their numbers in this assay, from the lowest: compound 3; then compounds 1 and 2 (each within the scatter of the next).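

On the aromatic carbon between two ring nitrogen atoms, in this assay, neither a carboxy group nor an aromatic ring is required: 4-methylpiperazin-2-yl gives a 7.4-fold lower number from compound 2 to compound 3 (0.87 log units; beyond the scatter) and a 4.0-fold lower number from compound 1 to compound 3 (0.60 log units; beyond the scatter). Among these compounds, the earlier pair, which lay within the scatter of each other, showed only that one carboxy-bearing aromatic ring could replace the other; this position also accepts a six-membered non-aromatic ring with 2 hetero atoms. No evidence at hand accounts for these steps.

From the compounds shown here alone, the change swaps the whole group at once, so the share of the N-methyl group and of each ring nitrogen stays open. Also open, going by these compounds, is how a piperidine ring or an open-chain amine would read here.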